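Lengthening an Isothiocyanate Chain on Two Sulfoxide Cores

The source may report more compounds than this note shows. Statements on the series, on what has been measured and on what is new or still open speak of the compounds shown alone.

Of the compounds shown here, three have so far been tested in a functional assay on MCF7 cells (Homo sapiens) for cytotoxicity, read by MTT assay, with a stated time of 72 h; a higher number here means a weaker inhibitor, a lower number a stronger inhibitor. Compound 1 `CC(C)[S+]([O-])CCCCN=C=S` gives 8820 nM in this assay, and compound 2 `CC(C)[S+]([O-])CCCN=C=S` gives 7930 nM. These two share a core and differ in one place only: a group of 4 heavy atoms (2 carbon, 1 nitrogen, 1 sulfur; no ring) in place of a group of 3 heavy atoms (1 carbon, 1 nitrogen, 1 sulfur; no ring), on a saturated chain carbon, three bonds along the chain from a sulfur. That change produced a 1.1-fold higher number from compound 2 to compound 1 (0.05 log units; within the scatter), so the two numbers cannot be told apart. Compound 3 `[O-][S+](CCCCCN=C=S)Cc1ccccc1` is built on another core; the difference between the two cores is not broken down here. In this assay compound 3 gives 3830 nM, the lowest of the three numbers, and its gaps to compound 2 and to compound 1 both lie beyond the scatter.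

Compound 4 `[O-][S+](CCCCCCN=C=S)Cc1ccccc1` has not yet been measured. It differs from compound 3 by the same kind of change that leads from compound 2 to compound 1: a group of 4 heavy atoms (2 carbon, 1 nitrogen, 1 sulfur; no ring) in place of a group of 3 heavy atoms (1 carbon, 1 nitrogen, 1 sulfur; no ring), on a saturated chain carbon, five bonds along the chain from a sulfur. The surroundings are not identical, however: in compound 4 the change sits five bonds along the chain from a sulfur, whereas in compound 1 it sits three bonds along the chain from a sulfur. Among the compounds with values here, the step from compound 3 to compound 4 is expected to be small, a 1.1-fold higher number from compound 3 to compound 4 (0.04 log units; within the scatter), because the only earlier instance of this change gave a 1.1-fold higher number from compound 2 to compound 1 (0.05 log units; within the scatter). Compound 4 is therefore expected to give about 4200 nM in this assay, most likely between 2100 nM and 8500 nM.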

Compound 4, half-maximal inhibitory concentration: 5490 nM
Compound 4: the middle estimate sits 1.3-fold (0.12 log units) below what was measured; the range from low to high includes it.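

In this assay, adding to the chain that carries the isothiocyanate gave a 1.4-fold higher number from compound 3 to compound 4 (0.16 log units; within the scatter), so this step cannot be told apart from no change at all. Set beside the earlier case, the same change reads alike on the two cores: the same change on two cores in this assay, a 1.1-fold higher number (0.05 log units; within the scatter) from compound 2 to compound 1 and a 1.4-fold higher number (0.16 log units; within the scatter) from compound 3 to compound 4, 1.3-fold (0.11 log units) apart, within the scatter of two such steps. Within the data shown here, this agreement rests on only two pairs of compounds, both with steps inside the scatter, so it shows that the change made no readable difference on either of these cores; it does not show that the step would stay this small on a further core or at other chain lengths, and it does not explain why the two steps agree.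

The compounds shown leave open how a longer chain, or an amine or a carboxylic acid in place of the isothiocyanate, would read in this assay. Also open, from the compounds shown here alone, is what a sulfone in place of the sulfoxide would do on either core.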